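The source may report more compounds than this note shows. Statements on the series, on what has been measured and on what is new or still open speak of the compounds shown alone.

The study concerns four compounds built on two related cores carrying the same extended aryl chain. Compound 1 `Oc1cccc2[nH]c(-c3ccc(-c4ccc(-c5ccc(F)cc5)cc4)cc3)nc12` and compound 2 `Oc1cccc2[nH]c(-c3ccc(-c4ccc(-c5ccc(C(F)(F)F)cc5)cc4)cc3)nc12` share one core; compound 3 `Cc1ccc2[nH]c(-c3ccc(-c4ccc(-c5ccc(F)cc5)cc4)cc3)nc2c1` and compound 4 `Cc1ccc2[nH]c(-c3ccc(-c4ccc(-c5ccc(C(F)(F)F)cc5)cc4)cc3)nc2c1` share the other. The difference between the two cores is not broken down here.

In a functional assay on MCF7 cells (Homo sapiens) for inhibition, read by sulforhodamine B assay (on this read-out higher numbers stand for weaker inhibition of growth and lower numbers for stronger inhibition of growth), compound 1 gives 3010 nM and compound 2 gives 2310 nM. The change from compound 1 to compound 2 is trifluoromethyl in place of fluoro on an aromatic carbon, and it made a 1.3-fold lower number from compound 1 to compound 2 (0.11 log units; within the scatter). Compound 3 gives 30200 nM in this assay, which stands apart from both compounds on the other core, so the core itself matters far more than the terminal group in this set.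

Compound 4 is not yet measured. The change from compound 3 to compound 4 is trifluoromethyl in place of fluoro on an aromatic carbon, the same change as that from compound 1 to compound 2, at the same place. Since that earlier step stayed within the scatter, the corresponding step for compound 4 is expected to be small as well, and compound 4 is expected to remain close to compound 3 in this assay. Among the compounds with values here, the expected step is a 1.3-fold lower number from compound 3 to compound 4 (0.10 log units; within the scatter), resting only on the single earlier pair. Compound 4 is accordingly estimated at 24000 nM in this assay, with a range from 10000 nM to 60000 nM.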

Compound 4, concentration for 50% growth inhibition: 31000 nM
The estimate for compound 4 lay 1.3-fold (0.11 log units) below the measured number, and the stated range covers the measured number.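

In this assay the exchange of fluoro for trifluoromethyl on the second core gave a 1.0-fold higher number from compound 3 to compound 4 (0.01 log units; within the scatter) and so agreed with the result on the first core: the same change on two cores in this assay, a 1.3-fold lower number (0.11 log units; within the scatter) from compound 1 to compound 2 and a 1.0-fold higher number (0.01 log units; within the scatter) from compound 3 to compound 4, 1.3-fold (0.13 log units) apart, within the scatter of two such steps

The exchange of the core with the trifluoromethyl end held fixed gave a 13-fold higher number from compound 2 to compound 4 (1.13 log units; beyond the scatter) and thus a far larger step than the terminal exchange on either core. What carries over from one core to the other is therefore an absence of effect: on both cores shown, going from 4-fluorophenyl to 4-(trifluoromethyl)phenyl leaves the number within the scatter, and the large gap between the cores persists with either end group. This rests on one pair per core in a single assay, and it does not show that the same would hold on a third core, nor does it show how the change would carry over on a core where the terminal group made a real difference.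

The compounds shown leave open how an amine or a carboxylic acid in place of the fluoro would behave on these two cores, and whether such a group would give the same step on both. They also leave open how much of the gap between the cores belongs to the hydroxy group and how much to the methyl group.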